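The compounds below may be only part of what the source reports. "The series", "measured", "known", "first", "only" and "open" are said of these compounds alone.

In a physicochemical assay for solubility, read by LC-MS, in phosphate buffer, with a stated time of 24 h, at pH 7.4 (on this read-out lower numbers stand for lower solubility and higher numbers for higher solubility), compound 1 `Cc1cc(-c2cnc(NCc3c(F)ccc4c3CCO4)c3cn[nH]c(=O)c23)n(C)n1` gives 1000 nM and compound 2 `CNC(=O)c1cc(-c2cnc(NCc3c(F)ccc4c3CCO4)c3cn[nH]c(=O)c23)n(C)n1` gives 7000 nM, so compound 2 holds the higher of the two numbers. Compound 3 `CN(c1ccn(C)n1)c1cnc(NCc2c(F)ccc3c2CCO3)c2cn[nH]c(=O)c12` comes from compound 2 by one change: methyl(1-methyl-1H-pyrazol-3-yl)amino in place of 1-methyl-3-(methylcarbamoyl)-1H-pyrazol-5-yl on an aromatic carbon. Among the measured compounds shown here, the methylcarbamoyl group leaves with it, and the only measured step involving that group is a 7.0-fold higher number from compound 1 to compound 2 (0.85 log units; beyond the scatter), modest but beyond the scatter. For the measured compounds named here, no measured step covers the entering methyl(1-methyl-1H-pyrazol-3-yl)amino group, so a drop of similar size is expected, with wide uncertainty. The expected step is a 3.5-fold lower number from compound 2 to compound 3 (0.54 log units; beyond the scatter). For compound 3 the estimated value is 2000 nM, with an expected range of 500 nM to 8000 nM.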

Compound 3, solubility: 12000 nM
The estimate for compound 3 lay 6.0-fold (0.78 log units) below the measured number, and the stated range ends below it.
By their numbers in this assay, from the lowest: compound 1; then compounds 2 and 3 (each within the scatter of the next).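

In this assay the position takes methyl(1-methyl-1H-pyrazol-3-yl)amino in place of 1-methyl-3-(methylcarbamoyl)-1H-pyrazol-5-yl with a 1.7-fold higher number from compound 2 to compound 3 (0.23 log units; within the scatter), so a number of this size does not need the methylcarbamoyl group at this aromatic carbon. In place of 1,3-dimethyl-1H-pyrazol-5-yl, the same entering group gives a 12-fold higher number from compound 1 to compound 3 (1.08 log units; beyond the scatter) as the step. Nothing at hand accounts for either step. Still open, on these data alone, is how a morpholine or a plain dimethylamino group would read at this position, and whether the pyrazole of the entering group matters there at all.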